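Notes on the acyl-side aryl change from compound 3 to compound 4

A few compounds are considered here, and "the series" means these few. Any claim that something is new, unique, unknown or untested is made for them only; others in the source may bear on it.

Compound 3 `COc1cc(OC)c(OC)cc1/C=C/C(=O)c1ccc(O)cc1O` is the reference here. In a functional assay on MCF7 cells (Homo sapiens) for inhibition, read by MTT assay, with a stated time of 72 h (a lower number here means a stronger inhibitor, a higher number a weaker inhibitor), compound 3 gives 33800 nM. Compound 1 `COc1ccc(C(=O)/C=C/c2cc(OC)c(OC)cc2OC)cc1` gives 33900 nM in this assay, and the two numbers sit level: a 1.0-fold lower number from compound 1 to compound 3 (0.00 log units; within the scatter). Compound 2 `COc1cc(OC)c(OC)cc1/C=C/C(=O)c1ccccc1` is reported in this assay only as a limit of the assay, > 150000 nM; see (the limit of > 150000 nM in this assay, at which 1 of the 3 values shown sits). Because of that limit the steps of an at least 4.4-fold higher number from compound 1 to compound 2 (0.64 log units; beyond the scatter) and an at least 4.4-fold lower number from compound 2 to compound 3 (0.64 log units; beyond the scatter) are known only as minimum sizes.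

Compound 4 `COc1cc(OC)c(OC)cc1/C=C/C(=O)c1cc(Cl)ccc1O` differs from compound 3 in one place: 5-chloro-2-hydroxyphenyl in place of 2,4-dihydroxyphenyl on a carbonyl carbon.

Within the data shown here, the steps that bear on this position are a 1.0-fold lower number from compound 1 to compound 3 (0.00 log units; within the scatter), which lay within the scatter, and an at least 4.4-fold lower number from compound 2 to compound 3 (0.64 log units; beyond the scatter), which was at least modest and pointed to a lower number when a hydroxyl-bearing ring replaced the plain phenyl. Among the measured compounds shown here, compound 4 keeps one hydroxyl on the ring at the carbonyl carbon, so the closest precedent is the flat step to compound 3 rather than the step from compound 2. Compound 4 is therefore expected to give a number near compound 3 in this assay, with a 1.0-fold higher number from compound 3 to compound 4 (0.02 log units; within the scatter) as the expected step. The estimate for compound 4 is 35000 nM, ranging from 12000 nM to 110000 nM.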

Compound 4, half-maximal inhibitory concentration: > 150000 nM
Compound 4 gave a limit, no number; the forecaster's own chance of this, stated with the estimate: 15%; middle value at least 4.2-fold (0.63 log units) from the limit.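

Compound 4 is reported in this assay only as a limit of the assay, not as a number: the limit of > 150000 nM in this assay, at which 2 of the 4 values shown sit.

The change on the carbonyl carbon is thus not flat, with an at least 4.4-fold higher number from compound 3 to compound 4 (0.64 log units; beyond the scatter) and an at least 4.4-fold higher number from compound 1 to compound 4 (0.64 log units; beyond the scatter), both known only as minimum sizes. The earlier compounds shown here left only the plain phenyl of compound 2 at the limit, while the 2,4-dihydroxyphenyl of compound 3 and the 4-methoxyphenyl of compound 1 sat level; compound 4 shows that keeping a hydroxyl on this ring does not by itself keep a readable number.

On these data alone, compound 2 and compound 4 are both limits, and the step between them cannot be read, so their order stays open. Also open, as far as these compounds go, is which difference goes with the higher number, the chlorine that enters or the hydroxyl that leaves; a 2-hydroxyphenyl on the carbonyl carbon, carrying neither the chlorine nor the second hydroxyl, would separate the two.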